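The source may hold more compounds than are shown below. What is called first, only, known or untested is meant among the compounds shown, and "the series" means these compounds.

Compound 1 `Oc1cccc(-c2cc(-c3ccc(F)cc3)cc(-c3ccccc3O)n2)c1` gives > 50000 nM in a functional assay on HCT-15 cells (Homo sapiens) for inhibition (a higher number here means a weaker inhibitor, a lower number a stronger inhibitor), a limit of the assay.
Compound 2 `Oc1ccccc1-c1cc(-c2ccc(C(F)(F)F)cc2)cc(-c2ccccc2O)n1` gives > 50000 nM in this assay, also a limit.
Compound 3 `Oc1cccc(-c2cc(-c3ccc(C(F)(F)F)cc3)cc(-c3ccccc3O)n2)c1` gives > 50000 nM in this assay, again a limit.

Compound 3 thus stands at the limit of > 50000 nM in this assay, at which 3 of the 3 values shown sit, so its place among the three cannot be ranked. Compound 4 `Oc1cccc(-c2cc(-c3ccc(OC(F)(F)F)cc3)cc(-c3ccccc3O)n2)c1` differs from it by trifluoromethoxy in place of trifluoromethyl on an aromatic carbon. The two measured steps that touch compound 3, a step that the two limits leave unreadable from compound 1 to compound 3 and a step that the two limits leave unreadable from compound 2 to compound 3, run between limits and give no readable size, so no direction can be drawn from them for a change on the same aromatic carbon. The step that the limit leaves unreadable from compound 3 to compound 4 is therefore expected to be none beyond the scatter. Compound 4 is expected to give about 80000 nM, with a range from 20000 nM to 300000 nM, most likely reported as a limit.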

Compound 4, half-maximal inhibitory concentration: 9410 nM
Beside the measured number, compound 4's estimate is 8.5-fold (0.93 log units) above it; the whole stated range lies above it.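

In this assay, trifluoromethoxy on the aromatic carbon para to a large group gives the first readable number, with an at least 5.3-fold lower number from compound 3 to compound 4 (0.72 log units; beyond the scatter) and an at least 5.3-fold lower number from compound 1 to compound 4 (0.72 log units; beyond the scatter). Within the data shown here, this position therefore responds to the group it carries, which the earlier compounds could not show, all of them sitting at one limit: the limit of > 50000 nM in this assay, at which 3 of the 4 values shown sit. The steps among those earlier compounds cannot be read.

Going by these compounds, what a methoxy group, an amine or a carboxylic acid would give on this carbon stays open. So does whether the 3-hydroxyphenyl group matters once trifluoromethoxy is present.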